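This account rests on a few compounds, and the source may have more. Where it says the series, first, only, none or still open, it means among the compounds named here.

In a functional assay on A-375 cells (Homo sapiens) for antiproliferative activity, read by MTT assay, with a stated time of 72 h (on this read-out higher numbers stand for weaker inhibition and lower numbers for stronger inhibition), compound 1 (`O=C1COc2ccc(-c3cccc(NS(=O)(=O)c4ccc(F)cc4)c3)cc2N1`) gives 20100 nM. Compound 2 (`CC(C)N1C(=O)COc2ccc(-c3cccc(NS(=O)(=O)c4ccc(F)cc4)c3)cc21`), with isopropyl on the amide-type nitrogen, is reported only as a limit, > 40000 nM. Compound 3 (`O=C1COc2ccc(-c3cccc(NS(=O)(=O)c4ccc(F)cc4)c3)cc2N1c1ccccc1`), with phenyl there, is also reported only as a limit, > 40000 nM. As far as these compounds go, compound 3 therefore stands at the limit of > 40000 nM in this assay, at which 2 of the 3 values shown sit, so its true position is unknown.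

Compound 4 (`COc1ccc(N2C(=O)COc3ccc(-c4cccc(NS(=O)(=O)c5ccc(F)cc5)c4)cc32)cc1`) changes that phenyl to 4-methoxyphenyl: methoxy in place of hydrogen on an aromatic carbon. The measured steps that bear on this change all concern the same nitrogen. They are an at least 1.9-fold higher number from compound 1 to compound 2 (0.29 log units; that floor lies within the scatter), an at least 1.9-fold higher number from compound 1 to compound 3 (0.29 log units; that floor lies within the scatter) and a step that the two limits leave unreadable from compound 2 to compound 3. None of them places methoxy in place of hydrogen on an aromatic carbon, so they give no direct size for this step. With an at least 1.9-fold higher number from compound 1 to compound 3 (0.29 log units; that floor lies within the scatter) as the nearest guide, no step beyond the scatter is expected in this assay, and compound 4 may well be reported as a limit again.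

The estimated step is an at least 1.0-fold lower number from compound 3 to compound 4 (0.02 log units; that floor lies within the scatter).

For compound 4, the expected value is 38000 nM, within an estimated range from 17000 nM to 70000 nM.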

Compound 4, half-maximal inhibitory concentration: 38500 nM
Compound 4: middle estimate off by 1.0-fold (0.01 log units), on the low side; measured number inside the range.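

Unlike compound 2 and compound 3, compound 4 carries a number rather than a limit in this assay, and adding methoxy to the phenyl group gives an at least 1.0-fold lower number from compound 3 to compound 4 (0.01 log units; that floor lies within the scatter). Exchanging isopropyl for 4-methoxyphenyl on the same nitrogen gives an at least 1.0-fold lower number from compound 2 to compound 4 (0.01 log units; that floor lies within the scatter), and exchanging the hydrogen there for 4-methoxyphenyl gives a 1.9-fold higher number from compound 1 to compound 4 (0.28 log units; within the scatter). So none of the three groups on this nitrogen is shown to move the number beyond the scatter, and the comparison stays tied to the assay limit: the limit of > 40000 nM in this assay, at which 2 of the 4 values shown sit.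

As far as these compounds go, the true positions of compound 2 and compound 3 remain unknown. From the compounds shown here alone, it is also open whether an amine or a carboxylic acid in place of the methoxy, or a methyl on the nitrogen, would give a number clearly apart from these.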